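Shortening a Fatty Chain: Expected Cytotoxicity of Compound 3

The source may report more compounds than this note shows. Statements on the series, on what has been measured and on what is new or still open speak of the compounds shown alone.

Compound 1 `CCCCCCCCCCCCCCCCOC(=O)NC(CCC(=O)O)(CCC(=O)O)CCC(=O)O`: 440000 nM
Compound 2 `CCCCCCCCCCCCCCCCCC(=O)NC(CCC(=O)O)(CCC(=O)O)CCC(=O)O`: "not determined" (no result reported)

In an ADME assay on cells (Epithelial cell, Homo sapiens) for cytotoxicity, read by MTT assay (on this read-out lower numbers stand for an effect already at smaller amounts and higher numbers for an effect only at larger amounts of compound), compound 1 gives 440000 nM, the only numerical result so far. For compound 2 the entry reads "not determined" (no result reported), so no number exists for it. Compound 3 `CCCCCCCCCCCCCCOC(=O)NC(CCC(=O)O)(CCC(=O)O)CCC(=O)O` differs from compound 1 by hydrogen in place of ethyl on a saturated chain carbon, ten or more bonds along the chain from an oxygen next to a carbonyl group. For the measured compounds named here, no measured pair of this kind is available to guide the expectation, so the step of a 1.2-fold higher number from compound 1 to compound 3 (0.07 log units; within the scatter) is expected to stay within the usual scatter, if anything leaning toward an effect only at larger amounts. Compound 3 is therefore estimated at 520000 nM, with a range from 250000 nM to 1100000 nM.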

Compound 3, half-maximal effective concentration: 620000 nM
The estimate for compound 3 lay 1.2-fold (0.08 log units) below the measured number, and the stated range covers the measured number.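

In this assay, hydrogen in place of ethyl on a saturated chain carbon, ten or more bonds along the chain from an oxygen next to a carbonyl group, gives a 1.4-fold higher number from compound 1 to compound 3 (0.15 log units; within the scatter). For the compounds shown here, this is the first measured step at this position, and it shows that removing these two carbons leaves the read-out within the usual scatter. Nothing measured here explains this result. As far as these compounds go, a longer chain or an amine in place of ethyl remains open, as does how much further shortening the chain would take to move the number beyond the scatter.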